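Two Six-Membered Rings in Place of One Five-Membered Ring

This account rests on a few compounds, and the source may have more. Where it says the series, first, only, none or still open, it means among the compounds named here.

Three measured compounds share a core in which a five-membered non-aromatic ring with one nitrogen and one sulfur carries a benzamide chain and, on its amide-type nitrogen, a varying aromatic group. Compound 1 `O=C(NCCCCc1ccccc1)c1cccc(C2SCC(=O)N2c2cccc(-c3c[nH]nn3)c2)c1` bears a phenyl ring that carries a three-hetero-atom ring; in a functional assay on HOS-TE85 cells (Homo sapiens) for inhibition, read by CCK-8 assay, with a stated time of 72 h (on this read-out lower numbers stand for stronger inhibition and higher numbers for weaker inhibition), compound 1 gives 110 nM. Compound 2 `O=C(NCCCCn1cccn1)c1cccc(C2SCC(=O)N2c2cccnc2)c1` differs at more than one place; in this assay compound 2 reaches only a limit, > 1000 nM. Compound 3 `CC(C)(C)c1conc1N1C(=O)CSC1c1cccc(C(=O)NCCCCc2ccccc2)c1` carries a five-membered aromatic ring with 2 hetero atoms on that nitrogen; in this assay compound 3 likewise reaches only a limit, > 1000 nM. Compound 3 therefore stands at the limit of > 1000 nM in this assay, at which 2 of the 3 values shown sit, together with compound 2, and below the measured value of compound 1. Among the measured compounds shown here, the one step that bears on this nitrogen substituent, an at least 9.0-fold higher number from compound 1 to compound 3 (0.95 log units; beyond the scatter), shows that leaving the phenyl-borne ring cost potency.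

Compound 4 `O=C(NCCCCc1ccccc1)c1cccc(C2SCC(=O)N2c2ccc(-c3ccccc3)cc2)c1` takes the change (a group of 12 heavy atoms (12 carbon; 2 six-membered aromatic rings of carbon only) in place of a group of 9 heavy atoms (7 carbon, 1 nitrogen, 1 oxygen; one five-membered aromatic ring with 2 hetero atoms), on an amide-type nitrogen in a ring). The entering group restores a six-membered aromatic ring of carbon only, as in compound 1, but without the three-hetero-atom ring. A partial return toward compound 1 is expected, because an at least 9.0-fold higher number from compound 1 to compound 3 (0.95 log units; beyond the scatter) was at least modest. For compound 4 the expected step is an at least 2.5-fold lower number from compound 3 to compound 4 (0.39 log units; beyond the scatter). Compound 4 is estimated at 400 nM, within 100 nM to 2000 nM.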

Compound 4, half-maximal inhibitory concentration: > 1000 nM
Compound 4 ended at the assay's limit; the forecaster's own chance of this, stated with the estimate: 35%; middle value at least 2.5-fold (0.39 log units) away from the limit.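

The 4-phenylphenyl group brings back a six-membered aromatic ring of carbon only on the amide-type nitrogen, yet compound 4 reaches only a limit of this assay, > 1000 nM. Measured against the group with the three-hetero-atom ring, the change gives an at least 9.0-fold higher number from compound 1 to compound 4 (0.95 log units; beyond the scatter), so a six-membered aromatic ring of carbon only at this position, even with a second such ring on it, is not enough to keep the potency seen in the series. The values of compound 3 and compound 4 are both limits, so the step between them cannot be read, and the set now gathers at a single end of the scale: the limit of > 1000 nM in this assay, at which 3 of the 4 values shown sit.

The compounds shown leave open whether the three-hetero-atom ring itself is what matters in compound 1, or whether another group carried by that phenyl ring, such as a carboxylic acid or an amine, would serve as well. They also leave open how compound 2, compound 3 and compound 4 rank among themselves, since a limit gives no number to compare.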